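This account rests on a few compounds, and the source may have more. Where it says the series, first, only, none or still open, it means among the compounds named here.

Working notes on the series. In a functional assay on HepG2 cells (Homo sapiens) for inhibition, read by MTT assay, with a stated time of 72 h (a lower number here means a stronger inhibitor, a higher number a weaker inhibitor), compound 1 (`Nc1nc2cc(-c3nn(CCCC(=O)NO)c4ncnc(N)c34)ccc2o1`) gives > 50000 nM, which is a limit of the assay and not a number. This places compound 1 at the limit of > 50000 nM in this assay, at which 1 of the 3 values shown sits. Compound 2 (`Nc1ncnc2c1c(-c1cnc3[nH]ccc3c1)nn2CCCCC(=O)NO`) gives 36700 nM, and compound 3 (`Nc1ncnc2c1c(-c1cnc3[nH]ccc3c1)nn2CCCCCCC(=O)NO`) gives 10300 nM.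

The next compound to be read in this assay is compound 4 (`CNC(=O)CCCCCCCn1nc(-c2ccc3oc(N)nc3c2)c2c(N)ncnc21`). Its change from compound 1 is 4-(methylcarbamoyl)butyl in place of hydroxycarbamoyl on a saturated chain carbon, three bonds along the chain from an aromatic nitrogen. The hydroxycarbamoyl group therefore gives way to 4-(methylcarbamoyl)butyl, on a saturated chain carbon, three bonds along the chain from an aromatic nitrogen.

For the measured compounds named here, one measured step bears on this, and only in part. It is the modest 3.6-fold lower number from compound 2 to compound 3 (0.55 log units; beyond the scatter), where 2-(hydroxycarbamoyl)ethyl takes the place of hydroxycarbamoyl. That step extends the chain, as the change to compound 4 does, but it keeps the hydroxycarbamoyl end, and compounds 2 and 3 also differ from compound 1 outside the chain. Going by the values given here, no measured step covers the exchange of hydroxycarbamoyl for methylcarbamoyl. No shift beyond the scatter is therefore expected, and a further reading at the limit would fit this expectation.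

The expected change is a number no higher from compound 1 to compound 4 (the limit leaves the size open). For compound 4 the estimated value is 50000 nM, with an expected range of 20000 nM to 120000 nM.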

Compound 4, half-maximal inhibitory concentration: 3640 nM
Beside the measured number, compound 4's estimate is 14-fold (1.14 log units) above it; measured number outside the range, below it.
By their numbers in this assay, from the lowest: compound 4; then compound 3; then compound 2. At a limit, above all of these: compound 1.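

In this assay, the exchange of hydroxycarbamoyl for 4-(methylcarbamoyl)butyl, on a saturated chain carbon, three bonds along the chain from an aromatic nitrogen, gives an at least 13-fold lower number from compound 1 to compound 4 (1.13 log units; beyond the scatter). This position therefore tolerates a change of both chain length and chain end on the core of compound 1, and a hydroxycarbamoyl end is not needed for a measurable reading, as compound 4 gives 3640 nM without one. The size of the step is a bound and not an exact figure, as the value for compound 1 is a limit of the assay: the limit of > 50000 nM in this assay, at which 1 of the 4 values shown sits.

The exchange brings in a longer chain and a methylcarbamoyl end together, so the compounds shown do not tell how much of the step belongs to each, and the only step that extends a chain, a 3.6-fold lower number from compound 2 to compound 3 (0.55 log units; beyond the scatter), sits on a different core and keeps the hydroxycarbamoyl end. A hydroxycarbamoyl end or a carboxylic acid on the chain length of compound 4 would be the direct comparison for separating the two parts of the change.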